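The source may hold more compounds than are shown below. What is called first, only, known or untested is meant among the compounds shown, and "the series" means these compounds.

Of the compounds shown here, three sharing one core have been tested in an ADME assay on HEK-293T cells (Homo sapiens) for inhibition, read by CCK-8 assay, with a stated time of 48 h, tested at 20 uM; on this read-out higher numbers stand for more inhibition of growth at the one concentration tested and lower numbers for less inhibition of growth. Compound 1 `COc1ccc(S(=O)(=O)Oc2ccccc2/C=C(\C#N)C(=O)Nc2nnc(Cc3ccccc3)s2)cc1` gives 23%, compound 2 `N#C/C(=C\c1ccccc1OS(=O)(=O)c1ccc(Cl)cc1)C(=O)Nc1nnc(Cc2ccccc2)s1` gives 25%, and compound 3 `N#C/C(=C\c1ccccc1OS(=O)(=O)c1ccc(F)cc1)C(=O)Nc1nnc(Cc2ccccc2)s1` gives 6%, the lowest of the three: a number 17 percentage points lower from compound 1 to compound 3 (beyond the scatter) and a number 19 percentage points lower from compound 2 to compound 3 (beyond the scatter), whereas a number 2 percentage points higher from compound 1 to compound 2 (within the scatter). Compound 4 `Cc1ccc(Cc2nnc(NC(=O)/C(C#N)=C/c3ccccc3OS(=O)(=O)c3ccc(F)cc3)s2)cc1` differs from compound 3 by methyl in place of hydrogen on an aromatic carbon, on the benzyl part of the core. Within the data shown here, none of the measured steps touches this part of the molecule; all three vary a substituent on a different ring, so they offer no direct guide to this change. Among the measured compounds shown here, with no comparable step to draw on, a change within the scatter is expected, a number 4 percentage points higher from compound 3 to compound 4 (within the scatter). Compound 4 is therefore estimated at 10%, with a range from -5% to 30%.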

Compound 4, percent growth inhibition at one concentration: 11%
Compound 4: the middle estimate sits 1 percentage points below what was measured, within the range that was stated.
By their numbers in this assay, from the lowest: compounds 3 and 4 (each within the scatter of the next); then compounds 1 and 2 (each within the scatter of the next).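

Methyl in place of hydrogen, para to a large group on the benzyl part of the core, is the first change read at this position, and in this assay it gives a small step (a number 5 percentage points higher from compound 3 to compound 4 (within the scatter)). With a fluoro on the other ring, then, phenyl and 4-methylphenyl cannot be told apart on this read-out. Nothing measured here bears on why.

Going by these compounds, it remains open whether an amine, a carboxylic acid or a longer chain at this position would move the number beyond the scatter. On these data alone, it also remains open whether methyl behaves the same with chloro or methoxy on the other ring.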